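The source may report more compounds than this note shows. Statements on the series, on what has been measured and on what is new or still open speak of the compounds shown alone.

In a functional assay on the whole organism (Tail, strain ICR) with Mus musculus as the target, in the tail flick test, with a stated time of 150 min, at a dose of 25 umol/kg by the oral route (a higher number here means a stronger effect of the compound at the dose given, a lower number a weaker effect), compound 1 `C[C@@H](O)[C@H](NC(=O)CN(c1nc(Cl)nc2[nH]cnc12)C1CC1)C(=O)OCc1ccccc1` gives 12.8%, the lowest of the three numbers measured. Among the measured compounds shown here, compound 2 `C[C@@H](O)[C@H](NC(=O)CN(c1nc(Cl)nc2[nH]cnc12)C1CC1)C(=O)O` gives 24%, and the only single-point step measured, a number 11.2 percentage points higher from compound 1 to compound 2 (beyond the scatter), concerns the ester end of the molecule. Compound 3 `N=C(N)NCCC[C@H](NC(=O)CN(c1ncnc2c1ncn2C1CCCCO1)C1CC1)C(=O)OCc1ccccc1` gives 19.6%; it differs from compound 1 in several places at once, so only the two values themselves can be compared, and they lie within the scatter of each other.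

Compound 4 `CSCC[C@H](NC(=O)CN(c1nc(Cl)nc2[nH]cnc12)C1CC1)C(=O)OCc1ccccc1` differs from compound 1 by 2-(methylsulfanyl)ethyl in place of 1-hydroxyethyl on a saturated chain carbon bound to an amide-type nitrogen and a carbonyl carbon. For the measured compounds named here, no measured step touches this side chain, so no step beyond the scatter is expected, and the estimate for compound 4 in this assay is 15%, with a range of 5% to 30%, meaning an expected step of a number 2.2 percentage points higher from compound 1 to compound 4 (within the scatter).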

Compound 4, a percentage reported as activity, at one dose (the size of the read-out at that dose, not a potency): 17.6%
Compound 4: middle estimate off by 2.6 percentage points, on the low side; the range from low to high includes it.
By their numbers in this assay, from the lowest: compounds 1, 4, 3 and 2 (each within the scatter of the next, the first and the last beyond it).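

In this assay, among the compounds shown here, the side chain on the saturated chain carbon bound to an amide-type nitrogen and a carbonyl carbon is probed for the first time, with a number 4.8 percentage points higher from compound 1 to compound 4 (within the scatter) for this exchange. The read-out at this dose thus does not separate 2-(methylsulfanyl)ethyl from 1-hydroxyethyl, although the exchange removes the hydrogen-bond donor of the side chain. No supporting data explain this outcome.

On these data alone, whether a primary amine, a carboxylic acid or a longer chain at this position would read apart from these two side chains stays open.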